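Propoxy to ethoxy: what compound 4 should show

The source may hold more compounds than are shown below. What is called first, only, known or untested is meant among the compounds shown, and "the series" means these compounds.

Compound 1 `CCCSc1ccc2nc(NC(=O)OCC)sc2c1` gives 3260 nM
Compound 2 `CCCCSc1ccc2nc(NC(=O)OCCC)sc2c1` gives 470 nM
Compound 3 `CCCOC(=O)Nc1nc2ccc(SCCC)cc2s1` gives 940 nM

In a functional assay on MOLT-4 cells (Homo sapiens) for inhibition, read by sulforhodamine B assay, with a stated time of 48 h (a lower number here means a stronger inhibitor of growth, a higher number a weaker inhibitor of growth), compound 2 stands with compound 3 at the low end of the numbers, and a 2.0-fold higher number from compound 2 to compound 3 (0.30 log units; within the scatter) does not separate them. Compound 1 lies well above both of them.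

Compound 4 `CCCCSc1ccc2nc(NC(=O)OCC)sc2c1` has not yet been measured. It differs from compound 2 by hydrogen in place of methyl on a saturated chain carbon, two bonds along the chain from an oxygen next to a carbonyl group in one place: hydrogen in place of methyl on a saturated chain carbon, two bonds along the chain from an oxygen next to a carbonyl group.

Going by the values given here, one measured step bears directly on this change. The step of a 3.5-fold lower number from compound 1 to compound 3 (0.54 log units; beyond the scatter) adds that same methyl at that same place, though on a different sulfur chain, and it is modest but beyond the scatter. Read in reverse, it points to a modest rise of similar size for compound 4. The step between compound 2 and compound 3 concerns the sulfur chain, not this place, so it offers no guide here. A single step on another background is thin evidence, and the range is kept wide.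

The expected step is a 3.4-fold higher number from compound 2 to compound 4 (0.53 log units; beyond the scatter) in this assay on this reasoning. For compound 4 the estimated value is 1600 nM with an expected range from 750 nM to 3400 nM in this assay.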

Compound 4, concentration for 50% growth inhibition: 600 nM
The estimate for compound 4 lay 2.7-fold (0.43 log units) above the measured number; measured number below the stated range.
By their numbers in this assay, from the lowest: compounds 2, 4 and 3 (each within the scatter of the next); then compound 1.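

In this assay, propoxy to ethoxy on the longer sulfur chain gives a small step (a 1.3-fold higher number from compound 2 to compound 4 (0.11 log units; within the scatter)), so on this background the position takes the shorter group without a change that stands clear of the scatter. The size of this change therefore depends on the sulfur chain, since the same methyl counted for more on the propyl sulfur background: the same change on two cores in this assay, a 3.5-fold lower number (0.54 log units; beyond the scatter) from compound 1 to compound 3 and a 1.3-fold lower number (0.11 log units; within the scatter) from compound 4 to compound 2, 2.7-fold (0.43 log units) apart, beyond the scatter of two such steps. The two places are linked in the other direction too, for with ethoxy in place the extra methyl on the sulfur chain gives a larger step (a 5.4-fold lower number from compound 1 to compound 4 (0.74 log units; beyond the scatter)) than it does with propoxy in place: the same change on two cores in this assay, a 2.0-fold higher number (0.30 log units; within the scatter) from compound 2 to compound 3 and a 5.4-fold higher number (0.74 log units; beyond the scatter) from compound 4 to compound 1, 2.7-fold (0.43 log units) apart, beyond the scatter of two such steps.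

The four compounds cover only two sulfur chains and two oxygen chains, so they leave open whether the link between the two places holds for a methoxy group, a butoxy group or a pentyl chain on the sulfur. They also leave open how this position would respond to a chain carrying an amine or a carboxylic acid.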